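Isobutoxy in place of methoxy on the shared core

This account rests on a few compounds, and the source may have more. Where it says the series, first, only, none or still open, it means among the compounds named here.

Among the measured compounds shown here, compound 1 `COc1cccc2occ(Cc3coc4ccccc4c3=O)c(=O)c12` gives 340 nM in a functional assay on ACHN cells (Homo sapiens) for antiproliferative activity, read by XTT assay (on this read-out lower numbers stand for stronger inhibition and higher numbers for weaker inhibition), the lowest of the three numbers so far. Compound 2 `O=c1c(Cc2coc3cccc(O)c3c2=O)coc2ccccc12` gives 740 nM, and compound 3 `O=C1c2c(OCC3CCCCC3)cccc2OCC1Cc1coc2ccccc2c1=O`, which carries a larger group in place of the methyl, gives 8200 nM. For the measured compounds named here, the one measured step, a 2.2-fold higher number from compound 1 to compound 2 (0.34 log units; beyond the scatter), shows that removing the methyl raises the number modestly; the values of compound 1 and compound 3 show that a much larger group raises it far more. Compound 4 `CC(C)COc1cccc2occ(Cc3coc4ccccc4c3=O)c(=O)c12` differs from compound 1 by isopropyl in place of hydrogen on a saturated chain carbon bound to an oxygen on an aromatic ring. Both comparisons point the same way, so a higher number is expected for compound 4, likely between the two. Compound 4 is therefore estimated at 1500 nM, with a range of 500 nM to 5000 nM. The expected step is a 4.4-fold higher number from compound 1 to compound 4 (0.64 log units; beyond the scatter).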

Compound 4, half-maximal inhibitory concentration: 1460 nM
Compound 4: the middle estimate sits 1.0-fold (0.01 log units) above what was measured, and the stated range covers the measured number.
By their numbers in this assay, from the lowest: compound 1; then compounds 2 and 4 (each within the scatter of the next); then compound 3.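

Lengthening methoxy to isobutoxy gives a 4.3-fold higher number from compound 1 to compound 4 (0.63 log units; beyond the scatter) in this assay and so raises the number only modestly on the shared core. Hydrogen and isobutyl on that oxygen cannot be ordered, with a 2.0-fold higher number from compound 2 to compound 4 (0.30 log units; within the scatter) as the whole gap, so methoxy alone stands apart from both here. Nothing available explains these differences.

Still open, from the compounds shown here alone, is how a longer chain on that oxygen would read. Going by these compounds, it is also open whether an amine or a carboxylic acid on the chain would change the number at all.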